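Chloro step on the phenyl ring of compound 1

This account rests on a few compounds, and the source may have more. Where it says the series, first, only, none or still open, it means among the compounds named here.

- compound 1 `COc1ccc(-c2nc3sc(-c4ccccc4)cn3n2)cc1` gives 49% 
- compound 2 `COc1cc(-c2nc(N)n(CC(=O)Nc3ccc(/C(C)=N\O)cc3)n2)cc(OC)c1OC` gives 5.54% 

In a functional assay on HOP-62 cells (Homo sapiens) for inhibition, read by sulforhodamine B assay, with a stated time of 48 h, tested at 10 uM (on this read-out lower numbers stand for less inhibition of growth and higher numbers for more inhibition of growth at the one concentration tested), compound 1 stands at 49% as the higher of the two numbers, and compound 2 at 5.54% lies lower by a gap beyond the scatter. Next comes compound 3 `COc1ccc(-c2nc3sc(-c4ccc(Cl)cc4)cn3n2)cc1` which differs from compound 1 by chloro in place of hydrogen on an aromatic carbon in one place: chloro in place of hydrogen on an aromatic carbon, para to a large group, so that phenyl becomes 4-chlorophenyl. Going by the values given here, no measured pair differs in one place, so no measured step can serve as a guide. A small upward shift is expected, with the estimated a number 4 percentage points higher from compound 1 to compound 3 (within the scatter) staying within the scatter. This expectation starts from compound 1 at 49% alone. For compound 3 the expected value is 53% with an estimated range from 32% to 74% for the coming measurement.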

Compound 3, percent growth inhibition at one concentration: 60.4%
Beside the measured number, compound 3's estimate is 7.4 percentage points below it, and the stated range covers the measured number.
By their numbers in this assay, from the lowest: compound 2; then compound 1; then compound 3.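

In this assay, going by these compounds alone, chloro in place of hydrogen on an aromatic carbon, para to a large group, reads a number 11.4 percentage points higher from compound 1 to compound 3 (beyond the scatter) and is the first single-place step. This carbon of the phenyl ring of compound 1 therefore accepts a chlorine atom, and growth inhibition at the one concentration tested rises rather than falls, though the step is modest. Nothing measured here bears on what lies behind this step.

A single step cannot show whether the rise is specific to chloro or would also appear with fluoro, methoxy or an amine on the same carbon. Going by these compounds, how chloro would read on the other carbons of that ring also remains open.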